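This account rests on a few compounds, and the source may have more. Where it says the series, first, only, none or still open, it means among the compounds named here.

Compound 1 `CCOC(=O)c1c(C)[nH]c(=O)c(C#N)c1-c1ccccc1` in a functional assay on HepG2 cells (Homo sapiens) for inhibition, read by MTT assay, with a stated time of 24 h; on this read-out lower numbers stand for stronger inhibition and higher numbers for weaker inhibition: 38500 nM
Compound 2 `CCOC(=O)c1c(C)[nH]c(=O)c(C#N)c1-c1ccc(C)cc1`: 11900 nM
Compound 3 `CCOC(=O)c1c(C)[nH]c(=O)c(C#N)c1-c1ccc(OC)cc1`: 51500 nM

Compound 3 stands at the highest of these three numbers; against compound 1 the gap lies within the scatter, against compound 2 the step of a 4.3-fold higher number from compound 2 to compound 3 (0.64 log units; beyond the scatter) lies beyond it. The step to compound 4 `CCOC(=O)c1c(C)[nH]c(=O)c(C#N)c1-c1ccc([N+](=O)[O-])cc1` is nitro in place of methoxy on an aromatic carbon. Within the data shown here, two measured steps touch the same position: a 1.3-fold higher number from compound 1 to compound 3 (0.13 log units; within the scatter) and a 4.3-fold higher number from compound 2 to compound 3 (0.64 log units; beyond the scatter), both modest or within scatter. No nitro group appears among the measured compounds, so the step in this assay cannot be anchored, and no change beyond the scatter is expected: the step is estimated as a 1.3-fold lower number from compound 3 to compound 4 (0.11 log units; within the scatter). For compound 4 the value in this assay is estimated at 40000 nM, within 14000 nM to 115000 nM.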

Compound 4, half-maximal inhibitory concentration: 21700 nM
Beside the measured number, compound 4's estimate is 1.8-fold (0.27 log units) above it, within the range that was stated.
By their numbers in this assay, from the lowest: compounds 2, 4, 1 and 3 (each within the scatter of the next, the first and the last beyond it).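

In this assay, nitro at this place on the aromatic ring separates from methoxy, with a 2.4-fold lower number from compound 3 to compound 4 (0.38 log units; beyond the scatter), a gap the earlier compounds had shown only for methyl. Yet a 1.8-fold higher number from compound 2 to compound 4 (0.26 log units; within the scatter) and a 1.8-fold lower number from compound 1 to compound 4 (0.25 log units; within the scatter), so nitro cannot be told apart from either methyl or hydrogen, even though those two differ from each other beyond the scatter. No evidence bearing on this result is available. Going by these compounds, whether an amine, a carboxylic acid or a longer chain at this place would fall outside the span of these four compounds stays open.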